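This account rests on a few compounds, and the source may have more. Where it says the series, first, only, none or still open, it means among the compounds named here.

In a functional assay on Right cardiac atrium for agonist activity at histamine H2 receptor (Cavia porcellus), with a stated time of 30 min, in the presence of a further agent that is not named here (on this read-out higher numbers stand for an effect only at larger amounts of compound and lower numbers for an effect already at smaller amounts), compound 1 `Cc1nc(N)sc1CCCN/C(N)=N/C(=S)N[C@@H](C)c1ccccc1` gives 224 nM, the highest of the two numbers recorded so far. Among the compounds with values here, the only other measured compound is compound 2 `CCCCCCNC(=O)/N=C(\N)NCCCc1sc(N)nc1C`, which in this assay gives 15.9 nM; the gap between compound 1 and compound 2 lies beyond the scatter of repeated measurements, so compound 1 is the weaker of the pair on this read-out. Compound 3 `Cc1nc(N)sc1CCCN/C(N)=N/C(=S)N[C@H](C)c1ccccc1` has not yet been measured. It is built from compound 1 by the change (the two compounds have the same atoms and bonds and differ only in configuration as drawn: 1 of 2 stereo elements differ; a stereocentre at a saturated chain carbon is drawn S in compound 1 and R in compound 3), so the two share every atom and bond and differ only in how the saturated chain carbon is drawn. Within the data shown here, no measured pair in this set shows how such a change affects this assay, so the direction of the step is open; the step from compound 1 to compound 3 is estimated to be small, a 1.3-fold higher number from compound 1 to compound 3 (0.13 log units; within the scatter), with room for a larger shift either way. Compound 3 is therefore expected to give about 300 nM in this assay, within a range from 70 nM to 1500 nM.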

Compound 3, half-maximal effective concentration: 89.1 nM
Beside the measured number, compound 3's estimate is 3.4-fold (0.53 log units) above it; low and high end bracket the measured number.
By their numbers in this assay, from the lowest: compound 2; then compound 3; then compound 1.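

Configuration at the saturated chain carbon is not silent in this assay: going from the S to the R drawing gives a 2.5-fold lower number from compound 1 to compound 3 (0.40 log units; beyond the scatter), a modest step but one that lies beyond the usual scatter. Within the data shown here, the earlier compounds held no pair that isolated this stereocentre, so this is the first reading of it, and within this one pair the R drawing gives the lower number. The step can be assigned to that stereocentre alone, and to no other part of the structure, because of one thing: the fact that compounds 1 and 3 differ only in the configuration as drawn.

From the compounds shown here alone, whether the same preference for the R drawing holds on other compounds remains open, since it rests on a single pair. Also open, going by these compounds, is how a longer chain at that saturated chain carbon would change the gap between the two drawings.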